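The compounds below may be only part of what the source reports. "The series", "measured", "known", "first", "only" and "open" are said of these compounds alone.

Of the compounds shown here, two carry numbers so far. Compound 1 `CCc1ccc(-c2ccc(N(C[C@@H](N)[C@@H](C)CC)C(=O)[C@@H]3C[C@H]3c3ccccc3)cc2)cc1` gives 44 nM in a functional assay for agonist activity at G protein-coupled receptor 88 (Homo sapiens), read by HTRF and cAMP accumulation (on this read-out higher numbers stand for an effect only at larger amounts of compound and lower numbers for an effect already at smaller amounts), and compound 2 `CC[C@H](C)[C@H](N)CN(C(=O)[C@@H]1C[C@H]1c1ccccc1)c1ccc(-c2ccc(CCC(=O)OC)cc2)cc1` gives 110 nM in this assay. Going by the values given here, compound 2 therefore stands at the higher of the two numbers, and the single step between them, a 2.5-fold higher number from compound 1 to compound 2 (0.40 log units; beyond the scatter), rests on one change: methoxycarbonyl in place of hydrogen on a saturated chain carbon, two bonds along the chain from an aromatic carbon.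

Compound 3 `CC[C@H](C)[C@H](N)CN(C(=O)[C@@H]1C[C@H]1c1ccccc1)c1ccc(-c2ccc(C(=O)N(C)C)cc2)cc1` has not yet been measured. It differs from compound 2 in one place: dimethylcarbamoyl in place of 2-(methoxycarbonyl)ethyl on an aromatic carbon, on an aromatic carbon of a six-membered aromatic ring of carbon only, para to a large group. Among the compounds with values here, the one measured step describes an addition to the chain that now leaves, and it was modest; no measured step speaks directly to dimethylcarbamoyl on that aromatic carbon. The most defensible expectation is thus a step within the scatter, leaning slightly toward the lower number of compound 1 because compound 1 with 44 nM also lacks the methoxycarbonyl-bearing chain. The step expected is a 1.4-fold lower number from compound 2 to compound 3 (0.14 log units; within the scatter). For compound 3 the estimate in this assay is 80 nM, within a range from 25 nM to 250 nM.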

Compound 3, half-maximal effective concentration: 980 nM
For compound 3 the middle estimate is 12-fold (1.09 log units) below the measured one; the whole stated range lies below it.
By their numbers in this assay, from the lowest: compound 1; then compound 2; then compound 3.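

The aromatic carbon para to a large group proves far more sensitive than the earlier pair suggested: in this assay the change to dimethylcarbamoyl brings an 8.9-fold higher number from compound 2 to compound 3 (0.95 log units; beyond the scatter), and set against the ethyl group of compound 1 the same position shows a 22-fold higher number from compound 1 to compound 3 (1.35 log units; beyond the scatter), which places compound 3 highest of the three. Compounds 1 and 2 had shown only a 2.5-fold higher number from compound 1 to compound 2 (0.40 log units; beyond the scatter), so a chain ending in an ester was already known to raise the number somewhat, whereas compound 3 shows that a group with fewer heavy atoms than 2-(methoxycarbonyl)ethyl can raise it much further, and that heavy-atom count alone does not set the order at this position. Nothing among the data shown explains this rise.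

The compounds shown leave open whether the higher number belongs to a carbonyl standing directly on the aromatic carbon or to the dimethylcarbamoyl group as a whole. A methoxycarbonyl group placed directly on that carbon, a dimethylcarbamoyl group carried at the end of an ethyl chain, or a carboxylic acid would help to separate these two readings.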